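Methyl for chloro on the shared core of compound 2

The compounds below may be only part of what the source reports. "The series", "measured", "known", "first", "only" and "open" are said of these compounds alone.

Compound 1, `C#CCn1cc(C(=O)NCCCOC(=O)[C@H]2OC(C)(C)N(C(=O)OC(C)(C)C)[C@@H]2c2ccccc2)c(=O)c2ccc(Cl)nc21`: in a functional assay on DU-145 cells (Homo sapiens) for cytotoxicity, read by MTT assay, with a stated time of 72 h (a lower number here means a stronger inhibitor, a higher number a weaker inhibitor), compound 1 gives > 10000 nM, a limit of the assay.
Compound 2, `C#CCn1cc(C(=O)NCCCOC(=O)[C@H]2CCCN2C(=O)OC(C)(C)C)c(=O)c2ccc(Cl)nc21`: in this assay compound 2 gives > 10000 nM, a limit of the assay.
Compound 3, `C#CCn1cc(C(=O)NCCCOC(=O)[C@H](C)NC(=O)OC(C)(C)C)c(=O)c2ccc(Cl)nc21`: in this assay compound 3 gives > 10000 nM, a limit of the assay.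

Compound 2 therefore stands at a limit only, and the two other values shown are limits as well. Among the compounds with values here, the one step between measured compounds, a step that the two limits leave unreadable from compound 2 to compound 3, cannot be read because the limit of > 10000 nM in this assay, at which 3 of the 3 values shown sit, covers both of its ends. Compounds 1 and 2 differ in the ester substituent, and their values show nothing more than that each sits at the limit.

Compound 4, `C#CCn1cc(C(=O)NCCCOC(=O)[C@H]2CCCN2C(=O)OC(C)(C)C)c(=O)c2ccc(C)nc21`, has not yet been measured. It differs from compound 2 by methyl in place of chloro on an aromatic carbon. Within the data shown here, no measured step touches that aromatic carbon, so the only guide is the limit of > 10000 nM in this assay, at which 3 of the 3 values shown sit. With every value at the limit, compound 4 is expected to give 20000 nM, estimated between 7000 nM and 60000 nM. The step from compound 2 to compound 4, a step that the limit leaves unreadable from compound 2 to compound 4, is thus expected to stay unreadable, most likely as a further limit.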

Compound 4, half-maximal inhibitory concentration: > 10000 nM
Compound 4 was reported as a limit; the forecaster's own chance of this, stated with the estimate: 85%; the middle value does not contradict the limit.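

In this assay compound 4 gives > 10000 nM, a limit of the assay. Compound 2 also stands at a limit, so no step can be read between compound 2 and compound 4, and what remains is this: the limit of > 10000 nM in this assay, at which 4 of the 4 values shown sit.

The compounds shown leave open how methyl in place of chloro would change a value that lies within the measurable range of this assay.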